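Iodo for fluoro on the side-chain ring: cytotoxicity outlook

The source may report more compounds than this note shows. Statements on the series, on what has been measured and on what is new or still open speak of the compounds shown alone.

Compound 1 `O=c1cc(CNCc2ccccc2Br)oc2ccc(O)c(O)c12` and compound 2 `O=c1cc(CNCc2ccc(F)cc2)oc2ccc(O)c(O)c12` share the same core and differ only in the aryl group on the saturated chain carbon bound to the amine nitrogen. In an ADME assay on Huh-7 cells (Homo sapiens) for cytotoxicity (a lower number here means that less compound is tolerated, a higher number that more compound is tolerated), compound 1 gives > 100000 nM, a limit of the assay. In this assay compound 2 gives > 100000 nM, also a limit. The step that the two limits leave unreadable from compound 1 to compound 2 therefore cannot be read. Compound 2 stands only at a limit, and both values shown sit at the limit of > 100000 nM in this assay, at which 2 of the 2 values shown sit.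

Compound 3 `O=c1cc(CNCc2ccc(I)cc2)oc2ccc(O)c(O)c12` carries iodo in place of fluoro on an aromatic carbon. Going by the values given here, no measured step bears on this change in readable form, since both neighbours end at the limit. Compound 3 is expected to sit at the limit as well, with a step that the limit leaves unreadable from compound 2 to compound 3 meaning no step beyond the scatter. The estimate for compound 3 in this assay is 150000 nM, within 60000 nM to 400000 nM.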

Compound 3, half-maximal cytotoxic concentration: 41700 nM
Estimate against measurement, compound 3: 3.6-fold (0.56 log units) above, and the stated range ends above it.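

In this assay, the side-chain ring substituent now proves able to shift the read-out: iodo in place of fluoro on an aromatic carbon, para to a large group, gives an at least 2.3-fold lower number from compound 2 to compound 3 (0.37 log units; beyond the scatter). The change to 4-iodophenyl from 2-bromophenyl gives an at least 2.3-fold lower number from compound 1 to compound 3 (0.37 log units; beyond the scatter), so both readable steps end on the same compound and both are open-ended in size. Compound 3 alone carries a number, the step between the two other compounds cannot be read, and the remaining values are limits: the limit of > 100000 nM in this assay, at which 2 of the 3 values shown sit.

Open, on these data alone, is whether chloro or methyl on that same aromatic carbon would also lower the number, or whether this is confined to iodo. Also open, as far as these compounds go, is how a longer chain between the amine nitrogen and the ring would read in this assay.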